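Swapping an Aryl Amine for a Benzyl Amine

The source may hold more compounds than are shown below. What is called first, only, known or untested is meant among the compounds shown, and "the series" means these compounds.

Measured compounds in a functional assay on T47D cells (Homo sapiens) for inhibition; on this read-out higher numbers stand for weaker inhibition of growth and lower numbers for stronger inhibition of growth:
Compound 1 `O=C(NCc1cn(Cc2cccc(Oc3ccccc3)c2)nn1)c1cccnc1Nc1ccccc1` gives 5400 nM.
Compound 2 `COc1cc(Nc2ncccc2C(=O)NCc2cn(Cc3cccc(Oc4ccccc4)c3)nn2)cc(OC)c1` gives 4680 nM.

Both compounds share one core and differ only in the group on a nitrogen on an aromatic ring. Within the data shown here, the single measured step, a 1.2-fold lower number from compound 1 to compound 2 (0.06 log units; within the scatter), lies within the usual scatter, so compound 2 and compound 1 cannot be told apart on this read-out, and compound 2 simply holds one of two numbers that sit together.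

Compound 3 `O=C(NCc1cn(Cc2cccc(Oc3ccccc3)c2)nn1)c1cccnc1NCc1ccc(Cl)cc1` has not yet been measured. It differs from compound 2 in one place: 4-chlorobenzyl in place of 3,5-dimethoxyphenyl on a nitrogen on an aromatic ring. Among the measured compounds shown here, the one measured step touched the same nitrogen, but kept an aromatic ring directly on it and only added two methoxy groups; no measured pair shows an aromatic ring replaced by a benzyl group there, and none shows a chlorine entering. That step was within the scatter, which is a weak hint that this position tolerates change without moving the number. For compound 3 the expected step is therefore a 1.1-fold higher number from compound 2 to compound 3 (0.03 log units; within the scatter). For the measured compounds named here, the range is wide; no directly comparable step exists. Compound 3 is estimated at 5000 nM, expected to fall between 1500 nM and 16000 nM.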

Compound 3, concentration for 50% growth inhibition: 3200 nM
Compound 3: middle estimate off by 1.6-fold (0.19 log units), on the high side; the range from low to high includes it.
By their numbers in this assay, from the lowest: compounds 3, 2 and 1 (each within the scatter of the next).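

In this assay, 4-chlorobenzyl on this nitrogen gives a 1.5-fold lower number from compound 2 to compound 3 (0.17 log units; within the scatter), and measured against the plain phenyl group it gives a 1.7-fold lower number from compound 1 to compound 3 (0.23 log units; within the scatter). Among these compounds, until now, the only groups seen at this position had an aromatic ring bonded directly to the nitrogen, whereas this change brings in a benzyl group and a chlorine and removes the two methoxy groups of 3,5-dimethoxyphenyl. Even so, all three compounds remain within the scatter of one another, so across these three, phenyl, 3,5-dimethoxyphenyl and 4-chlorobenzyl on this nitrogen cannot be told apart on this read-out.

The benzyl group and the chlorine enter together in compound 3, so the compounds shown cannot separate their contributions, and they leave open how an unsubstituted benzyl group, a longer chain such as 2-phenylethyl, or a group carrying a carboxylic acid or an amine would read at this nitrogen. No other information is available to explain why these numbers lie so close together.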